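Swapping Substituted Pyridyl Ethers and Membrane Permeability

The source may report more compounds than this note shows. Statements on the series, on what has been measured and on what is new or still open speak of the compounds shown alone.

Compound 2 `Cc1cnc(Oc2ccc3nc(COc4cccc(C(=O)O)c4)n(C)c3c2)c(F)c1` holds the higher of the two numbers in an ADME assay for permeability, using PAMPA, with a stated time of 4 h (a higher number here means that the compound crosses the layer faster, a lower number that the compound crosses the layer more slowly), giving 5.8 10^-6 cm/s, while compound 1 `Cn1c(COc2cccc(C(=O)O)c2)nc2ccc(Oc3ccccn3)cc21` gives 2.2 10^-6 cm/s in this assay. Compound 3 `Cc1cc(Cl)cnc1Oc1ccc2nc(COc3cccc(C(=O)O)c3)n(C)c2c1` differs from compound 2 by 5-chloro-3-methylpyridin-2-yl in place of 3-fluoro-5-methylpyridin-2-yl on an oxygen on an aromatic ring. For the measured compounds named here, the one measured step, a 2.6-fold higher number from compound 1 to compound 2 (0.42 log units; beyond the scatter), concerns a different change to the pyridyl at the same oxygen, so no step directly covers this swap. Since only the substituents on the pyridyl change, the step of a 1.1-fold higher number from compound 2 to compound 3 (0.05 log units; within the scatter) is expected to remain within the scatter. Compound 3 is therefore estimated at 6.5 10^-6 cm/s, with a range from 3.5 10^-6 cm/s to 12 10^-6 cm/s.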

Compound 3, apparent permeability: 13.7 10^-6 cm/s
For compound 3 the middle estimate is 2.1-fold (0.32 log units) below the measured one; the measured number lies above the stated range.
By their numbers in this assay, from the lowest: compound 1; then compound 2; then compound 3.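

In this assay, the swap of 3-fluoro-5-methylpyridin-2-yl for 5-chloro-3-methylpyridin-2-yl gives a 2.4-fold higher number from compound 2 to compound 3 (0.37 log units; beyond the scatter), so the substituents at this position still change the read-out when the heavy-atom, hydrogen-bond and charge counts stay the same. Against the plain pyridin-2-yl, the new group gives a 6.2-fold higher number from compound 1 to compound 3 (0.79 log units; beyond the scatter). The data shown offer no measured explanation for either step.

Going by these compounds, both the halogen and the methyl placement differ in compound 3, so the share of each in the step remains open. On these data alone, how an amine or a nitrile on the pyridyl would read also remains open.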